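Adding a phenyl group to compound 2

This account rests on a few compounds, and the source may have more. Where it says the series, first, only, none or still open, it means among the compounds named here.

Values measured in a functional assay on MDA-MB-231 cells (Homo sapiens) for antiproliferative activity, read by MTT assay, with a stated time of 48 h (on this read-out lower numbers stand for stronger inhibition and higher numbers for weaker inhibition), are available for two compounds:
- compound 1 (`O=C(CCN1C(=O)c2ccc(-c3ccccc3)cc2S1(=O)=O)Nc1ccc(C(=O)NO)cc1`) gives 3450 nM
- compound 2 (`O=C(CCCN1C(=O)c2ccccc2S1(=O)=O)Nc1ccc(C(=O)NO)cc1`) gives 8710 nM

Compound 2 has the higher of these two numbers, so it is the weaker inhibitor, and its gap to compound 1 lies beyond the usual scatter of repeat measurements. The next compound is compound 3 (`O=C(CCCN1C(=O)c2ccc(-c3ccccc3)cc2S1(=O)=O)Nc1ccc(C(=O)NO)cc1`). It is compound 2 with one change (phenyl in place of hydrogen on an aromatic carbon): phenyl in place of hydrogen on an aromatic carbon.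

For the measured compounds named here, no measured pair shows this single change alone. Compound 1 also carries the phenyl, but it differs from compound 2 in its chain as well, so the comparison is imperfect. Going by the values given here, the expectation therefore rests on compound 1 with its value of 3450 nM as the only measured compound holding a phenyl. In this assay the expected change is a 2.3-fold lower number from compound 2 to compound 3 (0.36 log units; beyond the scatter) toward a lower number, a moderate step that may prove small. The expected value for compound 3 is 3800 nM (estimated range 1400 nM to 9000 nM).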

Compound 3, half-maximal inhibitory concentration: 9900 nM
Compound 3: middle estimate off by 2.6-fold (0.42 log units), on the low side; measured number outside the range, above it.
By their numbers in this assay, from the lowest: compound 1; then compounds 2 and 3 (each within the scatter of the next).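

With the chain held the same, phenyl in place of hydrogen on an aromatic carbon gives a 1.1-fold higher number from compound 2 to compound 3 (0.06 log units; within the scatter) in this assay, so this single change, which adds a whole aromatic ring of six carbons, leaves the number indistinguishable from normal repeat variation. The lower number seen earlier therefore does not follow from the phenyl alone in this pair: with the phenyl present in both, compound 1, which has the shorter chain, gives 3450 nM and compound 3 gives 9900 nM in this assay, which points attention toward the chain as the place that differs between those two. Nothing among the available data gives a measured explanation for the lack of a clear shift with the phenyl.

The compounds shown leave open whether a different group on this same aromatic carbon, such as an amine or a carboxylic acid, would move the number where phenyl does not. They also leave open how a longer chain would read with the phenyl in place, and whether the chain of compound 1 would give a similar number without the phenyl.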